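Gastrin/cholecystokinin type B series: heteroaryl replacement at the anilide

The compounds below may be only part of what the source reports. "The series", "measured", "known", "first", "only" and "open" are said of these compounds alone.

Measured so far in a functional assay on gastric mucosa for displacement of a labelled ligand from Gastrin/cholecystokinin type B receptor (Canis lupus familiaris), read by CCK-8 assay; a lower number here means a stronger inhibitor, a higher number a weaker inhibitor:
- compound 1, `CC(C)(C)C(=O)CN1C(=O)N(CC(=O)Nc2ccc3ccn(CC(=O)O)c3c2)N=C(C2CCCCC2)c2ccccc21`, 2.4 nM
- compound 2, `O=C(O)CSc1cccc(NC(=O)CN2N=C(C3CCCCC3)c3ccccc3N(CC(=O)C3CCCC3)C2=O)c1`, 4.79 nM
- compound 3, `CC(C)(C)C(=O)CN1C(=O)N(CC(=O)Nc2cccc(-c3nc(=O)o[nH]3)c2)N=C(C2CCCCC2)c2ccccc21`, 4.47 nM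

All three measured compounds share the same core and differ only in the group carried on the anilide ring. Compound 3 holds the second highest of the three numbers in this assay; its nearest neighbour is compound 2 and its furthest is compound 1, and both of those gaps lie within the usual scatter, so the three compounds are not separated by this assay.

Compound 4, `CC(C)(C)C(=O)CN1C(=O)N(CC(=O)Nc2cccc(-c3nn[nH]n3)c2)N=C(C2CCCCC2)c2ccccc21`, is the next member. It differs from compound 3 in one place: a group of 5 heavy atoms (1 carbon, 4 nitrogen; one five-membered aromatic ring with 4 hetero atoms) in place of a group of 6 heavy atoms (2 carbon, 2 nitrogen, 2 oxygen; one five-membered aromatic ring with 3 hetero atoms), on an aromatic carbon. Both the group that leaves and the group that enters are five-membered aromatic rings rich in hetero atoms, each with one hydrogen-bond donor and three acceptors, placed on the same aromatic carbon.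

Within the data shown here, no measured pair in this set tracks a change of this kind directly. Given that three different groups at this position all give numbers within the scatter of one another, the expected step from compound 3 to compound 4 is a 1.0-fold higher number from compound 3 to compound 4 (0.00 log units; within the scatter), with no change beyond the scatter in either direction. The estimate for compound 4 in this assay is 4.5 nM, in the range 1.5 nM to 14 nM.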

Compound 4, inhibition constant: 3.16 nM
Beside the measured number, compound 4's estimate is 1.4-fold (0.15 log units) above it, and the stated range covers the measured number.
By their numbers in this assay, from the lowest: compounds 1, 4, 3 and 2 (each within the scatter of the next).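

In this assay, among these compounds, 2H-tetrazol-5-yl in place of the other five-membered aromatic ring gives a 1.4-fold lower number from compound 3 to compound 4 (0.15 log units; within the scatter), the first direct one-place step at this position on the anilide ring. The position, on an aromatic carbon of the six-membered ring and meta to a large group, thus takes either ring without a difference this assay can separate, even though a group of 5 heavy atoms replaces a group of 6 heavy atoms and the double bond outside the aromatic ring is lost. No measured property of either group is available to account for this result.

Among the compounds shown here, this step compares only two groups with the same hydrogen-bond donor and acceptor counts, so it leaves open how far the position's tolerance extends beyond five-membered aromatic rings rich in hetero atoms. A carboxylic acid or an amine placed directly on the same aromatic carbon, each compared with compound 4 on the same core, would test whether such a ring is needed there at all.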